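The source may report more compounds than this note shows. Statements on the series, on what has been measured and on what is new or still open speak of the compounds shown alone.

Measured compounds:
compound 1, `c1cc(Nc2nccc(-c3ccncc3)n2)cc(OCCn2ccnc2)c1`, giving 200 nM in a functional assay for inhibition, with Homo sapiens as the target; a lower number here means a stronger inhibitor, a higher number a weaker inhibitor;
compound 2, `c1cc(Nc2nccc(-c3cccnc3)n2)cc(OCCn2ccnc2)c1`, giving 100 nM;
compound 3, `NS(=O)(=O)c1ccc(Nc2nccc(-c3ccncc3)n2)cc1`, giving 5100 nM.

Compound 1 and compound 2 share one core and differ by pyridin-3-yl in place of pyridin-4-yl on an aromatic carbon. That change gave a 2.0-fold lower number from compound 1 to compound 2 (0.30 log units; within the scatter), a step that stays within the scatter of repeated measurements, so the two cannot be ranked against each other. Compound 3 carries a different core; the difference between the two cores is not broken down here. Its number is the highest of the three, and its gaps to compound 1 and to compound 2 both lie beyond the scatter.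

Compound 4, `NS(=O)(=O)c1ccc(Nc2nccc(-c3cccnc3)n2)cc1`, has not yet been measured in this assay. It stands to compound 3 exactly as compound 2 stands to compound 1: pyridin-3-yl in place of pyridin-4-yl on an aromatic carbon, at a place described in the same words, so this is the same change. For the measured compounds named here, the only measured example of it is a 2.0-fold lower number from compound 1 to compound 2 (0.30 log units; within the scatter), a small step. Because compound 3 starts at 5100 nM and a step of similar size is expected again, compound 4 is estimated at a 1.7-fold lower number from compound 3 to compound 4 (0.23 log units; within the scatter). Compound 4 is therefore expected to give about 3000 nM, most likely between 1200 nM and 7500 nM.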

Compound 4, half-maximal inhibitory concentration: 200 nM
Compound 4: middle estimate off by 15-fold (1.18 log units), on the high side, outside the stated range (below it).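

In this assay, putting pyridin-3-yl in place of pyridin-4-yl on the core of compound 3 gave a 26-fold lower number from compound 3 to compound 4 (1.41 log units; beyond the scatter), a large step from a change that only moves the nitrogen within the ring. The same change did not carry over at the same size from one core to the other: the same change on two cores in this assay, a 2.0-fold lower number (0.30 log units; within the scatter) from compound 1 to compound 2 and a 26-fold lower number (1.41 log units; beyond the scatter) from compound 3 to compound 4, 13-fold (1.11 log units) apart, beyond the scatter of two such steps. So in this series the size of the step depends on the core that carries it, but two pairs cannot predict its size on a third core or explain the gap, and the step on the core of compound 1 is too small to show that both steps truly run in the same direction.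

The compounds shown leave open how pyridin-2-yl or a plain phenyl ring would compare with these two pyridine groups. They also leave open how the change would behave on a core carrying an amine or a carboxylic acid in place of the sulfonamide.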